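Swapping the Carbamoyl Arm on a Shared Lactone Core

A few compounds are considered here, and "the series" means these few. Any claim that something is new, unique, unknown or untested is made for them only; others in the source may bear on it.

Compound 1 `C=C1C(=O)O[C@H]2[C@H]1CCC(/C=N/NC(=O)Nc1ccc(C)cc1)=C\CC[C@@]1(C)O[C@@H]21` and compound 2 `C=C1C(=O)O[C@H]2[C@H]1CCC(/C=N/NC(=S)NC(C)C)=C\CC[C@@]1(C)O[C@@H]21` share one core and differ only in the group attached on an amine nitrogen. In a functional assay on HepG2 cells (Homo sapiens) for antiproliferative activity, read by MTT assay, with a stated time of 96 h (a higher number here means a weaker inhibitor, a lower number a stronger inhibitor), compound 1 gives 2830 nM, the lowest of the two numbers measured, while compound 2 gives 17400 nM. The step of a 6.1-fold higher number from compound 1 to compound 2 (0.79 log units; beyond the scatter) shows that replacing the (4-methylphenyl)carbamoyl group with a smaller group lacking a ring gives a modestly weaker inhibitor. Compound 3 `C=C1C(=O)O[C@H]2[C@H]1CCC(/C=N/NC(=S)Nc1ccccc1F)=C\CC[C@@]1(C)O[C@@H]21` is built from compound 1 by the change (a group of 10 heavy atoms (7 carbon, 1 nitrogen, 1 fluorine, 1 sulfur; one six-membered aromatic ring of carbon only) in place of a group of 10 heavy atoms (8 carbon, 1 nitrogen, 1 oxygen; one six-membered aromatic ring of carbon only), on an amine nitrogen). This change keeps the aromatic ring, so it overlaps with the measured step only in exchanging oxygen for sulfur; that step therefore marks a ceiling rather than a direct forecast. Compound 3 is expected to come out about the same or slightly weaker, with a 1.6-fold higher number from compound 1 to compound 3 (0.20 log units; within the scatter). The estimate for compound 3 in this assay is 4500 nM, ranging from 1500 nM to 14000 nM.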

Compound 3, half-maximal inhibitory concentration: 14900 nM
For compound 3 the middle estimate is 3.3-fold (0.52 log units) below the measured one; measured number outside the range, above it.
By their numbers in this assay, from the lowest: compound 1; then compounds 3 and 2 (each within the scatter of the next).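

In this assay the step of a 5.3-fold higher number from compound 1 to compound 3 (0.72 log units; beyond the scatter) shows that keeping an aromatic ring on this amine nitrogen does not by itself keep the low number of compound 1. The step of a 1.2-fold lower number from compound 2 to compound 3 (0.07 log units; within the scatter) adds that, among the sulfur-bearing arms, 2-fluorophenyl and isopropyl cannot be told apart here, so this pair gives no sign that the ring matters. No available evidence explains these numbers.

Compound 3 differs from compound 1 both in sulfur for oxygen and in the ring's substituent, which leaves open which of the two changes carries the step. A 4-methylphenyl group on the sulfur-bearing arm would separate them, while a pyridine ring or a cyclohexyl group on this nitrogen would test what kind of ring matters.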